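The source may hold more compounds than are shown below. What is called first, only, known or untested is meant among the compounds shown, and "the series" means these compounds.

Measured in a functional assay on A549 cells (Homo sapiens) for inhibition, read by MTT assay, with a stated time of 72 h; a higher number here means a weaker inhibitor, a lower number a stronger inhibitor:

- Compound 1 `CCC/C=C\C(=O)Nc1cc(Nc2nc3c(c(-c4cn(C)c5ccccc45)n2)CSCC3)c(OC)cc1N(C)CCN(C)C` gives 571 nM
- Compound 2 `C=CC(=O)Nc1cc(Nc2nc3c(c(-c4cn(C)c5ccccc45)n2)CS(=O)(=O)CC3)c(OC)cc1N(C)CCN(C)C` gives 8690 nM
- Compound 3 `C=C(Cl)C(=O)Nc1cc(Nc2nc3c(c(-c4cn(C)c5ccccc45)n2)CS(=O)(=O)CC3)c(OC)cc1N(C)CCN(C)C` gives 881 nM

Compound 3, at 881 nM, lies within the usual scatter of compound 1 and well under compound 2. In compound 4 `C/C=C\C(=O)Nc1cc(Nc2nc3c(c(-c4cn(C)c5ccccc45)n2)CS(=O)(=O)CC3)c(OC)cc1N(C)CCN(C)C`, prop-1-en-1-yl takes the place of 1-chloroethenyl on a carbonyl carbon prop-1-en-1-yl in place of 1-chloroethenyl on a carbonyl carbon and so the chloro is lost.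

Going by the values given here, one measured step bears on this change: a 9.9-fold lower number from compound 2 to compound 3 (0.99 log units; beyond the scatter), with chloro in place of hydrogen on a double-bonded chain carbon bound to a carbonyl carbon. Compound 4 has no chloro either, so some of that drop may be reversed. Among the compounds with values here, how the extra carbon of prop-1-en-1-yl counts is unknown, since no single measured step shows it. Compound 1 differs from the others in more than one place and offers no clean comparison.

The change expected in this assay is an estimated 3.4-fold higher number from compound 3 to compound 4 (0.53 log units; beyond the scatter), a rise in the number that is less than the full size of the measured step. For compound 4 the estimate is 3000 nM, with an expected range from 800 nM to 10000 nM.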

Compound 4, half-maximal inhibitory concentration: 4260 nM
Estimate against measurement, compound 4: 1.4-fold (0.15 log units) below, within the range that was stated.
By their numbers in this assay, from the lowest: compounds 1 and 3 (each within the scatter of the next); then compound 4; then compound 2.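

In this assay, a 4.8-fold higher number from compound 3 to compound 4 (0.68 log units; beyond the scatter) shows that this position on the carbonyl carbon tells apart two groups with the same count of 3 heavy atoms and one double bond outside aromatic rings, so that count alone does not set the number. Against the vinyl group, a 2.0-fold lower number from compound 2 to compound 4 (0.31 log units; beyond the scatter) adds a second point: among these three compounds, which differ only in this group, the number is lowest with 1-chloroethenyl, intermediate with prop-1-en-1-yl and highest with vinyl. No measurement here explains why these groups differ.

On these data alone, it remains open how a 1-bromoethenyl group or an ethynyl group on the same carbonyl carbon would compare. As far as these compounds go, whether this order of the three groups would hold on a different core also remains open.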